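Ring closure of a pentyl chain on a shared core

The compounds below may be only part of what the source reports. "The series", "measured", "known", "first", "only" and "open" are said of these compounds alone.

Measured compounds and their values in a physicochemical assay for lipophilicity; on this read-out higher numbers stand for higher lipophilicity and lower numbers for lower lipophilicity:
Compound 1, `Brc1ccc(Br)c(N(CC2CC2)C2=NCCN2)c1`, gives -0.52.
Compound 2, `Brc1cccc(N(CC2CC2)C2=NCCN2)c1Br`, gives -0.41.
Compound 3, `CCCCCN(C1=NCCN1)c1c(Br)cccc1Br`, gives 0.32.

Three compounds share one core and differ in the group on the nitrogen and in where the two bromine atoms sit. Compound 3 stands highest of the three numbers in this assay. Its nearest neighbour is compound 2, whose value lies below it by more than the usual scatter, and compound 1 lies lower still, also by more than the scatter. Within the data shown here, no pair among the measured compounds differs in only one place, so no single measured step can be read off.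

Compound 4, `Brc1cccc(Br)c1N(CC1CCC1)C1=NCCN1`, has not yet been measured. It differs from compound 3 in one place: cyclobutyl in place of butyl on a saturated chain carbon bound to a nitrogen on an aromatic ring. Read one bond further out, a pentyl chain becomes a cyclobutylmethyl group.

Closing an open chain into a ring of the same count of carbon atoms generally shifts this assay by a small to moderate amount toward lower numbers, and that is what is expected here: the step of a number 0.37 log units lower from compound 3 to compound 4 (beyond the scatter) is expected to be somewhat beyond the scatter, downward. Compound 4 is therefore estimated at -0.05, with a range from -0.5 to 0.4.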

Compound 4, distribution coefficient: -0.06
The estimate for compound 4 lay 0.01 log units above the measured number; the range from low to high includes it.
By their numbers in this assay, from the lowest: compounds 1 and 2 (each within the scatter of the next); then compound 4; then compound 3.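

Among these compounds, compound 3 and compound 4 form the first pair here that differs in only one place, so the effect of a single change can finally be read: in this assay, replacing the open pentyl chain with a cyclobutylmethyl group gives a number 0.38 log units lower from compound 3 to compound 4 (beyond the scatter). The count of heavy atoms in the changed group stays the same and both groups are carbon only, so at this position, on a saturated chain carbon bound to a nitrogen on an aromatic ring, closing the ring is enough on its own to produce a modest step beyond the scatter. The measurements shown offer nothing that accounts for the size or direction of this step.

This remains a single pair, with one ring size and one arrangement of the two bromine atoms, so it sets no general rule. Going by these compounds, a longer chain such as hexyl, set against its closed counterpart cyclopentylmethyl, could show whether the same downward step appears with a larger ring, and the same closure on the bromine arrangement of compound 1 remains open too.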